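Amide Variation and Paw Edema Inhibition

The compounds below may be only part of what the source reports. "The series", "measured", "known", "first", "only" and "open" are said of these compounds alone.

Compound 1 `CCCCCNC(=O)CC1CCc2cc(OC)c(OC)cc21`: 35.2%
Compound 2 `COc1cc2c(cc1OC)C(CC(=O)N1CCCC1)CC2`: 22.2%
Compound 3 `COc1cc2c(cc1OC)C(CC(=O)N1CCOCC1)CC2`: 14.8%

In a functional assay on the whole organism (strain Wistar) for inhibition, with Rattus norvegicus as the target, read by paw edema, with stated times of 60 min and 6 h, at a dose of 100 mg/kg by the oral route (on this read-out higher numbers stand for more inhibition at the one dose given (going by the name of the read-out) and lower numbers for less inhibition), compound 3 stands lowest of the three numbers; its gap to compound 2 lies within the scatter, whereas the gap to compound 1 lies beyond it. Compound 4 `COc1cc2c(cc1OC)C(CC(=O)NCCO)CC2` differs from compound 3 by (2-hydroxyethyl)amino in place of morpholin-4-yl on a carbonyl carbon. The relevant measured steps are a number 13 percentage points lower from compound 1 to compound 2 (beyond the scatter) and a number 20.4 percentage points lower from compound 1 to compound 3 (beyond the scatter), both modest and beyond the scatter, putting the open-chain amide of compound 1 above the two cyclic amides, while a number 7.4 percentage points lower from compound 2 to compound 3 (within the scatter) stays within the scatter. Compound 4 returns to an open-chain amide, though a shorter one bearing a hydroxyl, and is therefore expected to move modestly upward, a number 7.2 percentage points higher from compound 3 to compound 4 (within the scatter). Compound 4 is estimated at 22%, in a range from 8% to 38%.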

Compound 4, a percentage reported as inhibition, in the whole organism at one dose (the size of the read-out at that dose, not a potency): 13%
Beside the measured number, compound 4's estimate is 9 percentage points above it; low and high end bracket the measured number.
By their numbers in this assay, from the lowest: compounds 4, 3 and 2 (each within the scatter of the next); then compound 1.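

In this assay an open chain on the carbonyl carbon does not by itself give the higher number: a number 1.8 percentage points lower from compound 3 to compound 4 (within the scatter) and a number 9.2 percentage points lower from compound 2 to compound 4 (within the scatter) both leave (2-hydroxyethyl)amino within the scatter of the two cyclic amides. Only pentylamino stands apart, since hydroxy in place of propyl gives a number 22.2 percentage points lower from compound 1 to compound 4 (beyond the scatter) and this lies beyond the scatter. Nothing measured here explains this result. On these data alone, whether a butyl or hexyl chain on the same carbonyl carbon, or a chain carrying a carboxylic acid or an amine, would match or pass compound 1 stays open.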